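Hydroxy on the ester side chain of compound 2

This account rests on a few compounds, and the source may have more. Where it says the series, first, only, none or still open, it means among the compounds named here.

Going by the values given here, compound 2 `CC[C@H](C)[C@H]1C(=O)N[C@H](Cc2cc(Cl)c(O)c(Cl)c2)C(=O)N[C@@H](C(C)C)C(=O)O[C@H](c2ccccc2)[C@H](C)/C=C/C=C(\C)[C@H](OC)C[C@@H]2O[C@@]2(C)C(=O)N1C` is the only member of the series with a numerical result: in a functional assay on HCT-116 cells (Homo sapiens) for antiproliferative activity, read by MTT assay, with a stated time of 72 h (on this read-out lower numbers stand for stronger inhibition and higher numbers for weaker inhibition), compound 2 gives 10.5 nM. Compound 1 `CC[C@H](C)[C@@H]1NC(=O)[C@]2(C)O[C@H]2C[C@@H](OC)/C(C)=C/C=C/[C@@H](C)[C@@H](c2ccccc2)OC(=O)[C@H](C(C)(C)O)NC(=O)[C@@H](Cc2cc(Cl)c(O)c(Cl)c2)NC1=O` reaches only the assay limit, > 1000 nM in this assay, which is a limit and not a number; one of the two values shown sits there (the limit of > 1000 nM in this assay, at which 1 of the 2 values shown sits). Among the compounds with values here, no step between measured compounds is available, so the two results of compound 1 and compound 2 stand side by side without a computed difference.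

Compound 3 `CC[C@H](C)[C@H]1C(=O)N[C@H](Cc2cc(Cl)c(O)c(Cl)c2)C(=O)N[C@@H](C(C)(C)O)C(=O)O[C@H](c2ccccc2)[C@H](C)/C=C/C=C(\C)[C@H](OC)C[C@@H]2O[C@@]2(C)C(=O)N1C` has not been measured. It differs from compound 2 in one place (hydroxy in place of hydrogen on a saturated chain carbon bound to two saturated chain carbons and a saturated ring carbon). With no measured step of this kind in the series, the expected step from compound 2 to compound 3 is set at a modest loss, a 3.8-fold higher number from compound 2 to compound 3 (0.58 log units; beyond the scatter), somewhat beyond the usual scatter. Compound 3 is accordingly estimated at 40 nM in this assay, with a range from 8 nM to 300 nM.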

Compound 3, half-maximal inhibitory concentration: 17 nM
For compound 3 the middle estimate is 2.4-fold (0.37 log units) above the measured one; low and high end bracket the measured number.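

In this assay, the change from isopropyl to 1-hydroxy-1-methylethyl gives a 1.6-fold higher number from compound 2 to compound 3 (0.21 log units; within the scatter), so hydroxy is tolerated on this saturated chain carbon. The methyl on the amide-type nitrogen in a ring now has a readable step, an at least 58-fold lower number from compound 1 to compound 3 (1.76 log units; beyond the scatter), which ties the large gap to that methyl and not to the hydroxy. The value of compound 1 is a limit of the assay and not a number, so this step has a bound and no exact size: the limit of > 1000 nM in this assay, at which 1 of the 3 values shown sits.

As far as these compounds go, whether an amine or a carboxylic acid on the same saturated chain carbon would also stay within the scatter of compound 2 remains open. Also open, from the compounds shown here alone, is how an ethyl on the amide-type nitrogen in a ring would compare with the methyl of compound 3.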